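Chloro for fluoro on the anilino ring of a pyrazole chalcone

A few compounds are considered here, and "the series" means these few. Any claim that something is new, unique, unknown or untested is made for them only; others in the source may bear on it.

Measured so far:
compound 1, `O=C(/C=C\Nc1ccc(Cl)cc1)c1cn(-c2ccccc2)nc1-c1ccccc1`, 11400 nM
compound 2, `O=C(/C=C\Nc1ccc(F)cc1)c1cn(-c2ccccc2)nc1-c1ccc(F)cc1`, 18200 nM

Both numbers come from a functional assay on U-87MG ATCC cells (Homo sapiens) for antiproliferative activity, read by MTT assay, with a stated time of 48 h; on this read-out higher numbers stand for weaker inhibition and lower numbers for stronger inhibition. Compound 2 holds the larger of the two numbers shown, yet its distance to compound 1 lies within the usual scatter, so the two cannot be told apart on this read-out. The step to compound 3, `O=C(/C=C\Nc1ccc(Cl)cc1)c1cn(-c2ccccc2)nc1-c1ccc(F)cc1`, is a single change: chloro in place of fluoro on an aromatic carbon. The same chloro group is already present in compound 1 on the same anilino ring, and compound 1 in this assay gives 11400 nM, a number that sits within the scatter of compound 2. For the measured compounds named here, no step between measured compounds isolates this change, so nothing beyond the two values is known. On that basis the step from compound 2 to compound 3 in this assay is expected to be small and in no clear direction, a 1.4-fold lower number from compound 2 to compound 3 (0.15 log units; within the scatter), within the scatter. Compound 3 is therefore estimated at 13000 nM, with a range from 5000 nM to 32000 nM.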

Compound 3, half-maximal inhibitory concentration: 8900 nM
Compound 3: the middle estimate sits 1.5-fold (0.16 log units) above what was measured; the measured number falls inside the stated range.
By their numbers in this assay, from the lowest: compounds 3, 1 and 2 (each within the scatter of the next, the first and the last beyond it).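

In this assay the change from (4-fluorophenyl)amino to (4-chlorophenyl)amino now has a step of its own, and a 2.0-fold lower number from compound 2 to compound 3 (0.31 log units; beyond the scatter) is a modest step that lies just beyond the scatter. The earlier pair could not show this, since compounds 1 and 2 differ in more than one place. The second new step, fluoro in place of hydrogen on an aromatic carbon, reads as a 1.3-fold lower number from compound 1 to compound 3 (0.11 log units; within the scatter) and stays within the scatter, so with chloro in place this fluoro has no effect that can be told apart on this read-out.

As far as these compounds go, how a methoxy group, an amine or a carboxylic acid in the place of the chloro would read remains open, and so does the effect of a bromo group, which would show whether the step continues beyond chloro. From the compounds shown here alone, it is also open whether the chloro-for-fluoro step would hold on the core of compound 1, which carries hydrogen where compound 3 carries its second fluoro. Nothing among the data shown explains why the chloro and fluoro compounds differ.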